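The source may hold more compounds than are shown below. What is called first, only, known or untested is meant among the compounds shown, and "the series" means these compounds.

Of the compounds shown here, three sharing one core have been measured in a functional assay on PC-3 cells (Homo sapiens) for antiproliferative activity, read by MTT assay, with a stated time of 72 h; on this read-out lower numbers stand for stronger inhibition and higher numbers for weaker inhibition. Compound 1 `O=C(N/N=C/c1ccc(F)cc1)Nc1ccc(Oc2ccnc3[nH]ccc23)c(F)c1` gives 2330 nM, compound 2 `O=C(N/N=C/c1cccc([N+](=O)[O-])c1)Nc1ccc(Oc2ccnc3[nH]ccc23)c(F)c1` gives 5140 nM and compound 3 `O=C(N/N=C/c1ccc(Cl)c(Cl)c1)Nc1ccc(Oc2ccnc3[nH]ccc23)c(F)c1` gives 14100 nM, which leaves compound 2 in the middle of the three. Compound 4 `O=C(N/N=C/c1ccc(O)cc1)Nc1ccc(Oc2ccnc3[nH]ccc23)c(F)c1` departs from compound 2 in one place: 4-hydroxyphenyl in place of 3-nitrophenyl on a carbon with a double bond to nitrogen.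

For the measured compounds named here, no measured step makes this exact exchange, and no compound with a hydroxyl group has been measured, but three exchanges on the same carbon bear on it. Replacing 4-fluorophenyl with 3-nitrophenyl gave a 2.2-fold higher number from compound 1 to compound 2 (0.34 log units; beyond the scatter), and replacing 3-nitrophenyl with 3,4-dichlorophenyl gave a 2.7-fold higher number from compound 2 to compound 3 (0.44 log units; beyond the scatter). The widest exchange gave a 6.1-fold higher number from compound 1 to compound 3 (0.78 log units; beyond the scatter), so all three were modest. The nearest measured group to 4-hydroxyphenyl is the 4-fluorophenyl of compound 1, at 2330 nM. A small move towards a lower number is therefore expected in this assay, probably not clearly beyond the scatter. The estimated change is a 1.5-fold lower number from compound 2 to compound 4 (0.17 log units; within the scatter). For compound 4 the estimate is 3500 nM, with an expected range of 1200 nM to 11000 nM.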

Compound 4, half-maximal inhibitory concentration: 2780 nM
For compound 4 the middle estimate is 1.3-fold (0.10 log units) above the measured one; measured number inside the range.
By their numbers in this assay, from the lowest: compounds 1, 4 and 2 (each within the scatter of the next, the first and the last beyond it); then compound 3.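

In this assay, for the compounds shown here, hydroxy in place of fluoro on an aromatic carbon gives a 1.2-fold higher number from compound 1 to compound 4 (0.08 log units; within the scatter) and 4-hydroxyphenyl in place of 3-nitrophenyl gives a 1.8-fold lower number from compound 2 to compound 4 (0.27 log units; within the scatter) and these are the first exchanges on this carbon that stay within the scatter, even though compound 1 and compound 2 remain apart from each other. The hydrogen-bond donor that enters with 4-hydroxyphenyl therefore leaves compound 4 within the scatter of both, while 3,4-dichlorophenyl stays set apart, with a 5.1-fold lower number from compound 3 to compound 4 (0.71 log units; beyond the scatter) as the step that shows it. Nothing available here gives a reason for these differences.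

The compounds shown leave open whether an amine or a methoxy group in place of the hydroxy would also stay within the scatter of compound 4. They also leave open how a carboxylic acid on this aromatic ring would compare.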